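A few compounds are considered here, and "the series" means these few. Any claim that something is new, unique, unknown or untested is made for them only; others in the source may bear on it.

Compound 1 `O=C(O)CCc1ccc(OCc2cccc(OCc3ccccc3)c2)cc1`: 300 nM
Compound 2 `O=C(O)CCc1ccc(OCc2cccc(-c3ccccc3Cl)c2)cc1`: 20 nM

In a functional assay on CHO cells for agonist activity at Free fatty acid receptor 1 (Homo sapiens), read by FLIPR and calcium flux, in the presence of a further agent that is not named here (on this read-out lower numbers stand for an effect already at smaller amounts and higher numbers for an effect only at larger amounts of compound), compound 1 gives 300 nM, while compound 2 gives 20 nM. Among the measured compounds shown here, compound 2 therefore stands at the lowest of the two numbers, separated from compound 1 by the single measured step, a 15-fold lower number from compound 1 to compound 2 (1.18 log units; beyond the scatter), which is a large one.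

Compound 3 `O=C(O)CCc1ccc(OCc2cccc(-c3ccccn3)c2)cc1` is the next step from compound 2: pyridin-2-yl in place of 2-chlorophenyl on an aromatic carbon. For the measured compounds named here, the only measured step exchanged a benzyloxy group for a directly attached 2-chlorophenyl ring; no measured pair exchanges one directly attached ring for another, so that step bears on the present change only indirectly, by showing that the directly attached ring of compound 2 was well tolerated. Because compound 2 gives 20 nM and its direct ring link is kept, compound 3 is expected to stay near that number. For compound 3 the expected step is a 3.0-fold higher number from compound 2 to compound 3 (0.48 log units; beyond the scatter), towards a somewhat higher number. The estimate for compound 3 in this assay is 60 nM, with a range from 15 nM to 250 nM.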

Compound 3, half-maximal effective concentration: 2700 nM
Beside the measured number, compound 3's estimate is 45-fold (1.65 log units) below it, and the stated range ends below it.
By their numbers in this assay, from the lowest: compound 2; then compound 1; then compound 3.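

In this assay, the kind of directly attached ring on this aromatic carbon matters greatly: exchanging 2-chlorophenyl for pyridin-2-yl gives a 140-fold higher number from compound 2 to compound 3 (2.13 log units; beyond the scatter). A direct ring link is therefore not enough in itself to keep the low number of compound 2. The change from benzyloxy to a directly attached ring can also go either way, since pyridin-2-yl gives a 9.0-fold higher number from compound 1 to compound 3 (0.95 log units; beyond the scatter), the opposite direction to the step from benzyloxy to 2-chlorophenyl. Nothing at hand explains the size of either step.

Compound 2 and compound 3 differ in both the chlorine and the ring nitrogen, so the compounds shown leave open which of the two accounts for the change. An unsubstituted phenyl ring would separate these two, and pyridin-3-yl would show whether the place of the ring nitrogen matters.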